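Removing the amino group from the core of compound 1

The compounds below may be only part of what the source reports. "The series", "measured", "known", "first", "only" and "open" are said of these compounds alone.

Compound 1 `CCOc1cc(C(Nc2ccc3c(N)nccc3c2)C(=O)NS(=O)(=O)c2cccc(S(N)(=O)=O)c2)ccc1OC(C)C` gives only a limit in an assay on isolated protein for inhibition of Trypsin (Homo sapiens) (a higher number here means a weaker inhibitor, a lower number a stronger inhibitor), namely > 5000 nM; at the limit of > 5000 nM in this assay, at which 1 of the 2 values shown sits, no number is known for it. Compound 2 `CCOc1cc(C(Nc2ccc3c(N)nccc3c2)C(=O)NS(=O)(=O)c2ccc(C)cc2)ccc1OC(C)C` gives 3040 nM, and the step of an at least 1.6-fold lower number from compound 1 to compound 2 (0.21 log units; that floor lies within the scatter) concerns the sulfonyl side and so does not bear on the change considered here. Compound 3 `CCOc1cc(C(Nc2ccc3cnccc3c2)C(=O)NS(=O)(=O)c2cccc(S(N)(=O)=O)c2)ccc1OC(C)C` differs from compound 1 by hydrogen in place of amino on an aromatic carbon. Among the measured compounds shown here, with compound 1 already at the limit, no measured step guides the size; compound 3 is estimated at 30000 nM, within 5000 nM to 300000 nM, the expected step being a step that the limit leaves unreadable from compound 1 to compound 3, most likely again a limit in this assay.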

Compound 3, inhibition constant: > 5000 nM
Compound 3: only a limit was reported (the forecaster's own chance of this, stated with the estimate: 90%); the middle value is on the limit's open side.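

Compound 1 and compound 3 both give only a limit in this assay, so no step between them can be read: the limit of > 5000 nM in this assay, at which 2 of the 3 values shown sit.

Going by these compounds, whether hydrogen in place of amino on an aromatic carbon changes the result in this assay remains open.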